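Substituted phenyl variation on the triarylethylene acrylic acid series

This account rests on a few compounds, and the source may have more. Where it says the series, first, only, none or still open, it means among the compounds named here.

Compound 3 `CC/C(=C(/c1ccc(/C=C/C(=O)O)cc1)c1ccc2[nH]ncc2c1)c1cccc(Cl)c1` gives the lowest number of the three compounds measured in a functional assay on MCF7 cells (Homo sapiens) for cytotoxicity, read by CellTiter-Glo, with a stated time of 5 days (a lower number here means a stronger inhibitor, a higher number a weaker inhibitor), at 12 nM. Among the compounds with values here, compound 2 `CC/C(=C(/c1ccc(/C=C/C(=O)O)cc1)c1cccc2[nH]ncc12)c1ccccc1` sits close by with 21 nM, and compound 1 `CC/C(=C(/c1ccc(/C=C/C(=O)O)cc1)c1ccc2[nH]c(=O)sc2c1)c1ccccc1` lies well behind with 158 nM; the one directly comparable pair, a 7.5-fold lower number from compound 1 to compound 2 (0.88 log units; beyond the scatter), concerns the fused bicyclic aryl rather than the phenyl group. Compound 4 `CC/C(=C(/c1ccc(/C=C/C(=O)O)cc1)c1ccc2[nH]ncc2c1)c1ccc(C#N)cc1Cl` carries 2-chloro-4-cyanophenyl in place of 3-chlorophenyl on a double-bonded chain carbon bound to a double-bonded chain carbon and a saturated chain carbon. Within the data shown here, no measured step touches this phenyl position, since compound 2 and compound 3 differ in two places at once. The author therefore expects no change beyond the scatter, estimating a 1.7-fold higher number from compound 3 to compound 4 (0.22 log units; within the scatter) in this assay, so that compound 4 is expected near 20 nM, within a range of 5 nM to 80 nM.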

Compound 4, half-maximal inhibitory concentration: 4 nM
Estimate against measurement, compound 4: 5.0-fold (0.70 log units) above, and the stated range ends above it.
By their numbers in this assay, from the lowest: compound 4; then compounds 3 and 2 (each within the scatter of the next); then compound 1.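

In this assay, this phenyl position on the double-bonded chain carbon now has a measured step of its own: 2-chloro-4-cyanophenyl in place of 3-chlorophenyl gives a 3.0-fold lower number from compound 3 to compound 4 (0.48 log units; beyond the scatter). The change at this place therefore moves the number beyond the scatter. No measurement shown accounts for this step. Going by these compounds, the step alters the chlorine's position and adds the nitrile together, so how much belongs to each remains open. On these data alone, whether an amine or a methoxy group in place of the nitrile would give a similar number also remains open.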